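The source may hold more compounds than are shown below. What is called first, only, known or untested is meant among the compounds shown, and "the series" means these compounds.

Compound 3 `CCCNC(=O)Nc1cc2nc(C3CCCCC3)[nH]c2cc1N(CC)CC` stands among three compounds tested in an ADME assay on Vero cells (Chlorocebus sabaeus) for cytotoxicity, read by resazurin assay, with a stated time of 3 days; a higher number here means a weaker inhibitor, a lower number a stronger inhibitor. In this assay compound 3 reaches only a limit, > 100 ug/mL, and no number. Compound 1 `CCN(CC)c1cc2[nH]c(C3CCCCC3)nc2cc1NC(=O)c1ccc(OC(F)(F)F)cc1` likewise gives only the limit > 100 ug/mL. Compound 2 `CCOCCOC(=O)Nc1cc2nc(C3CCCCC3)[nH]c2cc1N1CCCC1` also stops at the limit > 100 ug/mL. Within the data shown here, the single measured step, a step that the two limits leave unreadable from compound 1 to compound 3, has no readable size because of the limit of > 100 ug/mL in this assay, at which 3 of the 3 values shown sit. Compound 4 `CCOCCOC(=O)Nc1cc2nc(C3CCCCC3)[nH]c2cc1N(CC)CC` differs from compound 3 by 2-ethoxyethoxy in place of propylamino on a carbonyl carbon. Since every value shown sits at the same limit, the step is expected to stay within the scatter, at a step that the limit leaves unreadable from compound 3 to compound 4. Compound 4 is therefore expected to give about 150 ug/mL, in a range from 80 ug/mL to 400 ug/mL, most likely reported once more as a limit rather than a number.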

Compound 4, half-maximal inhibitory concentration: > 100 ug/mL
Compound 4: a limit, no number; the forecaster's own chance of this, stated with the estimate: 85%; the middle value does not contradict the limit.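

No step can be read between compound 4 and compound 1, compound 2 or compound 3, because each value is a limit, not a number: the limit of > 100 ug/mL in this assay, at which 4 of the 4 values shown sit.
Whether any of these compounds differ in this assay stays open.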